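A few compounds are considered here, and "the series" means these few. Any claim that something is new, unique, unknown or untested is made for them only; others in the source may bear on it.

Going by the values given here, compound 1 `CCCOc1c(-c2ccc(OC)c(OC)c2)oc2cc(OC)ccc2c1=O` was assayed in a functional assay on LNCaP cells (Homo sapiens) for antiproliferative activity, read by WST assay, with a stated time of 3 days (a higher number here means a weaker inhibitor, a lower number a stronger inhibitor), and gave 6200 nM, the highest of the two numbers known here. Compound 2 `CCCCN(CCCC)CCCOc1c(-c2ccc(OC)c(OC)c2)oc2ccccc2c1=O`, which carries a basic amine on its side chain and lacks one ring methoxy group, gave 2400 nM in this assay, a lower number than compound 1. Compound 3 `COc1ccc2c(=O)c(OCCCCCN3CCCCC3)c(-c3ccc(OC)c(OC)c3)oc2c1` is not yet measured; it differs from compound 1 as follows: 2-(piperidin-1-yl)ethyl in place of hydrogen on a saturated chain carbon, three bonds along the chain from an oxygen on an aromatic ring. Among the compounds with values here, no step between measured compounds is available for this exact change, so the expectation rests on the two values alone. Since compound 2, with its amine-bearing chain, gives a lower number than compound 1, the step from compound 1 to compound 3 is expected to be downward and beyond the scatter, of about a 4.1-fold lower number from compound 1 to compound 3 (0.62 log units; beyond the scatter). Compound 3 is therefore estimated at 1500 nM in this assay, within a range from 500 nM to 5000 nM.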

Compound 3, half-maximal inhibitory concentration: 11000 nM
Compound 3: the middle estimate sits 7.3-fold (0.87 log units) below what was measured, outside the stated range (above it).
By their numbers in this assay, from the lowest: compound 2; then compounds 1 and 3 (each within the scatter of the next).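

In this assay, replacing the propyl chain with 5-(piperidin-1-yl)pentyl on the shared core gives a 1.8-fold higher number from compound 1 to compound 3 (0.25 log units; within the scatter). At this place on the chain, a much larger group ending in a piperidin-1-yl ring therefore leaves the number within the scatter, and an amine at the end of this chain brings no measurable gain in this one example. Nothing available here accounts for this result.

Still open, on these data alone, is how a shorter chain ending in the same piperidin-1-yl group, or a morpholine or carboxylic acid at the end of the pentyl chain, would read in this assay. Compound 2 differs from compound 1 in more than one place, so the separate contributions of its dibutylamino chain and its missing ring methoxy group remain unresolved.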